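Pyrazolone amide series: aryl swap on the ring nitrogen

The source may hold more compounds than are shown below. What is called first, only, known or untested is meant among the compounds shown, and "the series" means these compounds.

Measured so far in a functional assay on MCF7 cells (Homo sapiens) for cytotoxicity, read by MTT assay, with a stated time of 72 h; a higher number here means a weaker inhibitor, a lower number a stronger inhibitor:
compound 1 `Cc1cc(=O)n(-c2ccc(Br)cc2F)nc1C(=O)Nc1ccc(Oc2ncnc3[nH]ccc23)c(F)c1` gives 26600 nM.
compound 2 `Cc1cc(=O)n(-c2ccc(Br)cc2F)nc1C(=O)Nc1ccc(Oc2ncnc3c2ccn3C)c(F)c1` reports only a limit, > 60000 nM, which is the assay limit and not a number.

Among the measured compounds shown here, the one measured step, an at least 2.2-fold higher number from compound 1 to compound 2 (0.35 log units; beyond the scatter), is supported by the limit of > 60000 nM in this assay, at which 1 of the 2 values shown sits. Compound 2 thus stands at the weak end of what this assay can report. Compound 3 `Cc1cc(=O)n(-c2ccccc2C(F)(F)F)nc1C(=O)Nc1ccc(Oc2ncnc3c2ccn3C)c(F)c1` differs from compound 2 by 2-(trifluoromethyl)phenyl in place of 4-bromo-2-fluorophenyl on an aromatic nitrogen. For the measured compounds named here, no measured step touches this position, so nothing here sets the direction. Compound 3 is expected near the limit again, estimated at 60000 nM (range 15000 nM to 200000 nM). The expected step is a number no higher from compound 2 to compound 3 (the limit leaves the size open).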

Compound 3, half-maximal inhibitory concentration: > 60000 nM
Compound 3: no number, only a limit (the forecaster's own chance of this, stated with the estimate: 60%); the middle value sits exactly at the limit.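

In this assay compound 3 gives > 60000 nM, a limit and not a number. Compound 2 also reports only a limit, so the step between compound 2 and compound 3 cannot be read. The compounds shown leave open whether 2-(trifluoromethyl)phenyl and 4-bromo-2-fluorophenyl differ at all in this cytotoxicity read-out.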